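The source may report more compounds than this note shows. Statements on the series, on what has been measured and on what is new or still open speak of the compounds shown alone.

Measured compounds:
- compound 1, `NCCC(=O)Nc1cccc2c1cnn2S(=O)(=O)c1cccc2ccccc12`: 7.9 nM
- compound 2, `CN(C)CCC(=O)Nc1ccc2cnn(S(=O)(=O)c3cccc4ccccc34)c2c1`: 1.8 nM

In an assay on HeLa cells for displacement of a labelled ligand from 5-hydroxytryptamine receptor 6 (Homo sapiens) (a lower number here means a stronger inhibitor, a higher number a weaker inhibitor), compound 1 gives 7.9 nM. In this assay compound 2 gives 1.8 nM, the lowest of the two numbers, and its gap to compound 1 lies beyond the usual scatter. Compound 3, `CCN(CC)CCC(=O)Nc1ccc2cnn(S(=O)(=O)c3cccc4ccccc34)c2c1`, has not yet been measured. It differs from compound 2 in one place: diethylamino in place of dimethylamino on a saturated chain carbon, two bonds along the chain from a carbonyl carbon. Among the measured compounds shown here, no pair of measured compounds differs in this way, so the effect of enlarging the amine has not been observed here. The account expects the change to move the number little, with a 1.7-fold higher number from compound 2 to compound 3 (0.22 log units; within the scatter) taken as a step not beyond the scatter, perhaps a slight rise. Compound 3 is therefore estimated to give 3 nM in this assay, within a range from 1 nM to 9 nM.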

Compound 3, inhibition constant: 2.1 nM
The estimate for compound 3 lay 1.4-fold (0.15 log units) above the measured number; the range from low to high includes it.
By their numbers in this assay, from the lowest: compounds 2 and 3 (each within the scatter of the next); then compound 1.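

Diethylamino in place of dimethylamino, on a saturated chain carbon, two bonds along the chain from a carbonyl carbon, gives a 1.2-fold higher number from compound 2 to compound 3 (0.07 log units; within the scatter) in this assay and so leaves the two compounds indistinguishable. Among the compounds shown here, this is the first step seen at this position, and it shows that going from the 3 heavy atoms of dimethylamino to the 5 of diethylamino does not carry the number beyond the scatter. Nothing measured here offers an explanation for this result.

On these data alone, it remains open whether a cyclic amine such as piperidine or morpholine, or a longer chain between the amine and the carbonyl, would also stay within the scatter of compound 2. Also open, as far as these compounds go, is how dimethylamino or diethylamino would read on the core of compound 1.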